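The source may report more compounds than this note shows. Statements on the series, on what has been measured and on what is new or still open speak of the compounds shown alone.

Working notes on the series. Compound 3 `c1ccc2c(c1)CN[C@@H](CN(CCN1CCNCC1)[C@H]1CCCc3cccnc31)C2` is the reference point; in an ADME assay on microsomes from liver (Mus musculus) for metabolic stability, read by LC-MS, with a stated time of 10 min, tested at 0.5 uM (on this read-out lower numbers stand for a less stable compound and higher numbers for a more stable compound), compound 3 gives 79%. Among the three measured compounds it stands second highest. Compound 2 `c1ccc2c(c1)CN[C@@H](CN(CCCCN1CCNCC1)[C@H]1CCCc3cccnc31)C2` gives 96% in this assay, and compound 1 `c1cnc2c(c1)CN[C@H](CN(CCCN1CCNCC1)[C@H]1CCCc3cccnc31)C2` gives 63%, so compound 3 sits between them, beyond the scatter from either.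

The next compound is compound 4 `c1ccc2c(c1)CN[C@@H](CN(CCCN1CCN(C3CC3)CC1)[C@H]1CCCc3cccnc31)C2`. It differs from compound 3 in one place: (4-cyclopropylpiperazin-1-yl)methyl in place of piperazin-1-yl on a saturated chain carbon, two bonds along the chain from an amine nitrogen.

Going by the values given here, only one measured step bears on this change, and only in part. Among the compounds with values here, the step of a number 17 percentage points lower from compound 2 to compound 3 (beyond the scatter) describes a chain one carbon shorter on the same saturated chain carbon; compound 4 reverses that direction, lengthening the chain by one carbon, but also places a cyclopropyl on the far piperazine nitrogen, for which no measured pair exists. Within the data shown here, compound 1 carries two changes at once relative to compound 3 and gives no clean step. Compound 4 is therefore expected to move by a number 1 percentage points lower from compound 3 to compound 4 (within the scatter) in this assay, a step that is not expected to exceed the scatter, given the opposing uncertainty about the cyclopropyl. The estimate for compound 4 in this assay is 78%, expected to fall between 50% and 96%.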

Compound 4, percent of the compound remaining: 3%
Beside the measured number, compound 4's estimate is 75 percentage points above it; measured number outside the range, below it.
By their numbers in this assay, from the lowest: compound 4; then compound 1; then compound 3; then compound 2.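

In this assay, going by these compounds alone, the change at this saturated chain carbon, two bonds along the chain from an amine nitrogen, gives large steps in both comparisons, with a number 76 percentage points lower from compound 3 to compound 4 (beyond the scatter) and with a number 93 percentage points lower from compound 2 to compound 4 (beyond the scatter) as well, whereas the one earlier step at this place, a number 17 percentage points lower from compound 2 to compound 3 (beyond the scatter), was modest and joined two compounds that both end in a plain piperazin-1-yl group. Compound 4 is the only compound shown that carries the 4-cyclopropylpiperazin-1-yl group, so the size of a chain change between plain piperazine compounds does not carry over once that group is present. Nothing at hand accounts for a step of this size.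

Both new steps alter the chain and bring in the cyclopropyl ring together, so the compounds shown do not separate the two changes. A plain piperazin-1-yl group on the chain of compound 4, or a 4-methylpiperazin-1-yl or 4-acetylpiperazin-1-yl group on that same chain, would show whether the loss follows the cyclopropyl ring, any group on that piperazine, or the chain itself.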